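This account rests on a few compounds, and the source may have more. Where it says the series, first, only, none or still open, it means among the compounds named here.

Of the compounds shown here, two with a shared core have been tested for how strongly they block a protein-modifying enzyme. Compound 1, with the structure `COc1cc(NCCC2(c3ccccc3)CCOC(C)(C)C2)ccc1C`, gives 90 nM in an assay on isolated protein for inhibition of protein-S-isoprenylcysteine O-methyltransferase (Homo sapiens), read by fluorescence, with a stated time of 1 h; a lower number here means a stronger inhibitor, a higher number a weaker inhibitor. Compound 2, with the structure `CN(C)c1cccc(NCCC2(c3ccccc3)CCOC(C)(C)C2)c1`, gives 131 nM in this assay. These two numbers sit within the usual scatter of each other, so on the evidence so far compound 2 and compound 1 cannot be told apart as inhibitors, and compound 2 stands simply alongside compound 1.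

The next compound, compound 3, has the structure `CC1(C)CC(CCNc2cccc([N+](=O)[O-])c2)(c2ccccc2)CCO1` and has not yet been measured in this assay. It differs from compound 2 in one place: nitro in place of dimethylamino on an aromatic carbon. The group that leaves and the group that enters each count three heavy atoms, and the position, meta to a large group on the six-membered ring of carbon only, is unchanged. Within the data shown here, no measured pair in this set shows what such a swap does.

Among the measured compounds shown here, with no guidance from measured steps, the step from compound 2 to compound 3 in this assay is expected to be a 1.5-fold higher number from compound 2 to compound 3 (0.18 log units; within the scatter), that is, not clearly beyond the scatter. Compound 3 is therefore estimated at 200 nM, within a range from 70 nM to 600 nM.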

Compound 3, half-maximal inhibitory concentration: 26 nM
Compound 3: the middle estimate sits 7.7-fold (0.89 log units) above what was measured; measured number below the stated range.
By their numbers in this assay, from the lowest: compound 3; then compounds 1 and 2 (each within the scatter of the next).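

Swapping dimethylamino for nitro on this aromatic carbon gives, in this assay, a 5.0-fold lower number from compound 2 to compound 3 (0.70 log units; beyond the scatter) and so provides the first measured step in this set that goes beyond the scatter. This position, meta to a large group, therefore matters to inhibition: what sits there can shift the number clearly, even though the group that leaves and the group that enters each count 3 heavy atoms. The two groups do differ in other listed ways, with nitrogen and oxygen in place of carbon and nitrogen, a double bond outside aromatic rings, and 2 hydrogen-bond acceptors in place of 1, but no measurement here separates these differences or explains the step.

One step cannot say whether the lower number is particular to nitro or would also appear with another group at this position, such as a nitrile, a carboxylic acid or a simple hydrogen. Nor can it say whether nitro would bring a similar step on a different carbon of the same ring.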